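The compounds below may be only part of what the source reports. "The series", "measured", "known", "first", "only" and "open" are said of these compounds alone.

Measured so far:
compound 1 `CC(=O)Nc1nn(-c2ccccc2)c(=O)c2ccccc12`: 0%
compound 2 `O=C(Nc1ccccc1Cl)Nc1nn(-c2ccccc2)c(=O)c2ccccc12`: 49%

In an assay on CHO cells for displacement of a labelled ligand from adenosine receptor A3 (Homo sapiens), tested at 1 uM (a higher number here means more inhibition at the concentration tested (going by the name of the read-out), a lower number less inhibition), compound 1 gives 0%, the lowest of the two numbers. Among the measured compounds shown here, compound 2 gives 49%; the one measured step, a number 49 percentage points higher from compound 1 to compound 2 (beyond the scatter), came with (2-chlorophenyl)amino in place of methyl on a carbonyl carbon.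

Compound 3 `CC(=O)N(C(C)=O)c1nn(-c2ccccc2)c(=O)c2ccccc12` is not yet measured. It differs from compound 1 by acetyl in place of hydrogen on an amide-type nitrogen, so the acetamido of compound 1 becomes a diacetylamino. The measured step does not bear on this change: it swapped the group on the carbonyl carbon, while here the amide-type nitrogen gains a second acetyl and loses its hydrogen. With compound 1 at the bottom of the series, no large step is expected; the number for compound 3 is estimated to stay near that of compound 1, a number 6 percentage points higher from compound 1 to compound 3 (within the scatter), within the scatter. Compound 3 is expected to give about 6%, in the range 0% to 28%.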

Compound 3, a percentage reported as inhibition, at one concentration (the size of the read-out at that concentration, not a potency): 0%
Compound 3: middle estimate off by 6 percentage points, on the high side, within the range that was stated.
By their numbers in this assay, from the lowest: compounds 1 and 3 (each within the scatter of the next); then compound 2.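

In this assay, acetyl in place of hydrogen on the amide-type nitrogen gives no change at the digits printed from compound 1 to compound 3 (within the scatter), so going from acetamido to diacetylamino brings no measurable inhibition at the concentration tested. With compound 1 already at 0%, this step could not reveal a loss, so it shows only that this acetyl does not raise the read-out on the core of compound 1. No measurement at hand gives a reason for this result.

On these data alone, whether acetyl on the amide-type nitrogen would have any effect alongside the (2-chlorophenyl)amino group of compound 2 remains open, since a change there could be seen in either direction from 49%. Also open, as far as these compounds go, is how a longer alkyl chain or a simple amine on the carbonyl carbon would read.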